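The compounds below may be only part of what the source reports. "The series", "measured", "known", "first", "only" and "open" are said of these compounds alone.

Working notes on the series. Of the compounds shown here, two have been measured. Compound 1 `COc1ccc(-c2cc(/C=C/C(=O)c3cc(OC)c(OC)c(OC)c3)[nH]n2)cc1OC` gives -94% in a functional assay on NCI-H522 cells (Homo sapiens) for cytotoxicity, read by sulforhodamine B assay, with a stated time of 48 h, tested at 10 uM; a lower number here means a stronger effect, a higher number a weaker effect of the compound at the concentration tested. Compound 2 `COc1ccc(C(=O)/C=C/c2cc(-c3cc(OC)c(OC)c(OC)c3)n[nH]2)cc1OC` gives -95% in this assay; this is the lower of the two numbers, yet compound 1 lies within the scatter of it, so no order can be read between them.

Compound 3 `COc1cc(C(=O)/C=C/c2cc(-c3cc(OC)c(OC)c(OC)c3)n[nH]2)cc(OC)c1OC` differs from compound 2 by methoxy in place of hydrogen on an aromatic carbon. Among the compounds with values here, no measured pair isolates this change. With compound 1 and compound 2 sitting within the scatter of each other in this assay, no step beyond the scatter is expected. The expected step is a number 2 percentage points higher from compound 2 to compound 3 (within the scatter). Compound 3 is estimated at -93%, within -99% to -78%.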

Compound 3, a percentage reported as activity, at one concentration (the size of the read-out at that concentration, not a potency): -97%
Beside the measured number, compound 3's estimate is 4 percentage points above it; low and high end bracket the measured number.
By their numbers in this assay, from the lowest: compounds 3, 2 and 1 (each within the scatter of the next).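

In this assay, methoxy in place of hydrogen on an aromatic carbon gives a number 2 percentage points lower from compound 2 to compound 3 (within the scatter), and the second comparison gives a number 3 percentage points lower from compound 1 to compound 3 (within the scatter). Within the data shown here, this position, ortho to a methoxy group and meta to a large group, therefore accepts methoxy with the read-out staying within the scatter of the earlier compounds. No measurement on hand bears on the reason for this result.

As far as these compounds go, with all three compounds this close at a single concentration, their potency order remains open. Also open, from the compounds shown here alone, is whether an amine or a carboxylic acid at this position would keep the read-out.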